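This account rests on a few compounds, and the source may have more. Where it says the series, first, only, none or still open, it means among the compounds named here.

Measured so far:
- compound 1 `CCC(C)NC(=O)/C=C/c1c(/C=C/c2ccc(OC)cc2)cc(OC)cc1OC`: 4380 nM
- compound 2 `COc1ccc(/C=C/c2cc(OC)cc(OC)c2/C=C/C(=O)NC2CC2)cc1`: 10200 nM

In a functional assay on B16-F10 cells (Mus musculus) for inhibition, read by MTT assay, with a stated time of 48 h (a lower number here means a stronger inhibitor, a higher number a weaker inhibitor), compound 1 stands lowest of the two numbers; the only other measured point is compound 2, reached by a 2.3-fold higher number from compound 1 to compound 2 (0.37 log units; beyond the scatter). Compound 3 `COc1ccc(/C=C/c2cc(OC)cc(OC)c2/C=C/C(=O)N2CCCCC2)cc1` differs from compound 1 by piperidin-1-yl in place of (sec-butyl)amino on a carbonyl carbon. Among the measured compounds shown here, the one step that bears on it is the substituent change on the same amide nitrogen, a 2.3-fold higher number from compound 1 to compound 2 (0.37 log units; beyond the scatter), which is modest but beyond the scatter; the present change is larger, as the hydrogen-bond donor is lost and a ring enters. A step of similar size toward a higher number is therefore expected, a 2.1-fold higher number from compound 1 to compound 3 (0.31 log units; beyond the scatter). Compound 3 is estimated at 9000 nM, with a range from 3500 nM to 25000 nM.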

Compound 3, half-maximal inhibitory concentration: 9750 nM
The estimate for compound 3 lay 1.1-fold (0.03 log units) below the measured number, within the range that was stated.
By their numbers in this assay, from the lowest: compound 1; then compounds 3 and 2 (each within the scatter of the next).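

On this carbonyl carbon in this assay a ring without a hydrogen-bond donor gives a 2.2-fold higher number from compound 1 to compound 3 (0.35 log units; beyond the scatter) and so moves the number the same way as cyclopropylamino did. Against the cyclopropyl amide, piperidin-1-yl shows a 1.0-fold lower number from compound 2 to compound 3 (0.02 log units; within the scatter) and leaves (sec-butyl)amino alone at the low end of the three. No measurement at hand explains either step. Open, from the compounds shown here alone, are an open-chain dialkylamino group such as diethylamino and a morpholin-4-yl ring on the same carbonyl carbon. Also open, going by these compounds, is whether a chain longer than sec-butyl on the amide nitrogen lowers the number further.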